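Acetylating the aniline nitrogen of a potent styryl sulfone

This account rests on a few compounds, and the source may have more. Where it says the series, first, only, none or still open, it means among the compounds named here.

Compound 1 `COc1cc(OC)c(/C=C/S(=O)(=O)Cc2ccc(OC)c(N)c2)c(OC)c1` stands at the lower limit of a functional assay on HCT-116 cells (Homo sapiens) for cytotoxicity, read by MTT assay, with a stated time of 72 h (a lower number here means a stronger inhibitor of growth, a higher number a weaker inhibitor of growth), giving < 10 nM (the limit of < 10 nM in this assay, at which 1 of the 3 values shown sits), a limit rather than a number. Compound 3 `COc1ccc(CS(=O)(=O)/C=C/c2c(OC)cccc2OC)cc1N`, in this assay, gives 20 nM, and the step of an at least 2.0-fold higher number from compound 1 to compound 3 (0.30 log units; that floor lies within the scatter) is at its floor within the scatter. Compound 2 `COc1ccc(OC)c(NC(=O)CS(=O)(=O)Cc2ccc(OC)c([N+](=O)[O-])c2)c1` sits at the upper limit of this assay, giving > 30000 nM (the limit of > 30000 nM in this assay, at which 1 of the 3 values shown sits), again a limit only. Compound 4 `COc1cc(OC)c(/C=C/S(=O)(=O)Cc2ccc(OC)c(NC(C)=O)c2)c(OC)c1` differs from compound 1 by acetyl in place of hydrogen on a nitrogen on an aromatic ring. Among the compounds with values here, no measured step touches this nitrogen, so the expectation rests only on the strength of compound 1. A modest loss is expected, an at least 4.0-fold higher number from compound 1 to compound 4 (0.60 log units; beyond the scatter), with the number for compound 4 estimated at 40 nM, between 8 nM and 300 nM.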

Compound 4, concentration for 50% growth inhibition: 150 nM
Compound 4: middle estimate off by 3.8-fold (0.57 log units), on the low side; the measured number falls inside the stated range.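

In this assay, acetyl in place of hydrogen on the aromatic nitrogen gives an at least 15-fold higher number from compound 1 to compound 4 (1.17 log units; beyond the scatter). The only earlier step, hydrogen in place of methoxy, has its floor within the scatter, so this is the first single change shown to bring a loss beyond it. That size is only a floor because compound 1 stands at a limit of the assay: the limit of < 10 nM in this assay, at which 1 of the 4 values shown sits.

As far as these compounds go, whether a methyl group or a longer acyl chain such as propionyl on this nitrogen would cost as much remains open. So does whether acetyl would bring a similar loss on compound 3.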